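The source may report more compounds than this note shows. Statements on the series, on what has been measured and on what is new or still open speak of the compounds shown alone.

Compound 1 `C=CC(=O)N1CCN(S(=O)(=O)c2ccc(NC(=O)OCc3ccccc3)cc2)CC1`: > 6 h
Compound 2 `C=CC(=O)NC1CCN(S(=O)(=O)c2ccc(C(=O)NCc3ccccc3)cc2)CC1`: > 6 h

Both entries come from an ADME assay on a cell-free system (plasma, Mus musculus) for metabolic stability, tested at 1 uM (a lower number here means that the compound disappears faster, a higher number that the compound lasts longer), and neither is a number. Compound 1 gives > 6 h, which is a limit of the assay. For the measured compounds named here, compound 2 gives > 6 h, which is also a limit, and it is the only reading for this compound. The evidence so far is therefore (the limit of > 6 h in this assay, at which 2 of the 2 values shown sit), so no measured difference separates the two compounds.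

Compound 3 `C=CC(=O)NC1CCN(S(=O)(=O)c2ccc(C(=O)N[C@@H]3C[C@H]3c3ccccc3)cc2)CC1` is the next compound to be tested in this assay. It carries 2-phenylcyclopropyl in place of benzyl on an amide-type nitrogen. Going by the values given here, no measured pair shows what a change at this place does, so the expectation has little to rest on. It starts from compound 2 at > 6 h, and no step beyond the usual scatter is expected, in either direction. The expected step that the limit leaves unreadable from compound 2 to compound 3 is an estimate that stays within that scatter. A report of only a limit is the likeliest outcome. For compound 3 the estimated half-life is 7 h, with an expected range of 4 h to 12 h.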

Compound 3, half-life: > 6 h
Compound 3 gave a limit, no number; the forecaster's own chance of this, stated with the estimate: 75%; the middle value is on the limit's open side.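

In this assay, for the compounds shown here, compound 2 and compound 3 both give only a limit, so no step between them can be read for 2-phenylcyclopropyl in place of benzyl on an amide-type nitrogen. The compounds shown leave open what their actual half-lives are and whether this change alters the half-life at all, since all of them sit at one limit: the limit of > 6 h in this assay, at which 3 of the 3 values shown sit.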